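The source may report more compounds than this note shows. Statements on the series, on what has been measured and on what is new or still open speak of the compounds shown alone.

Measured compounds and their values:
compound 1, `O=C(O)c1cccc(C2CC2c2ccc(OCc3c(-c4c(Cl)cccc4Cl)noc3C3CC3)cc2Cl)c1`: 53%
compound 2, `O=C(O)c1ccc(C2CC2c2ccc(OCc3c(-c4c(Cl)cccc4Cl)noc3C3CC3)cc2Cl)cc1`: 44%
compound 3, `O=C(O)c1cccc([C@H]2C[C@](O)(c3ccc(OCc4c(-c5c(Cl)cccc5Cl)noc4C4CC4)cc3Cl)C2)c1`: 49%

All three compounds were run in an ADME assay on the whole organism (strain C57BL/6J) for pharmacokinetics, with Mus musculus as the target, at a dose of 5 mg/kg by the oral route; on this read-out higher numbers stand for higher oral bioavailability and lower numbers for lower oral bioavailability. Compound 1 and compound 2 share one core and differ by 4-carboxyphenyl in place of 3-carboxyphenyl on a saturated ring carbon; the step between them is a number 9 percentage points lower from compound 1 to compound 2 (within the scatter). Compound 3 gives 49% in this assay, a number that sits close to those of compound 1 and compound 2, with both gaps within the scatter. How the core of compound 3 differs from the core of compound 1 is not broken down here.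

Compound 4, `O=C(O)c1ccc([C@H]2C[C@](O)(c3ccc(OCc4c(-c5c(Cl)cccc5Cl)noc4C4CC4)cc3Cl)C2)cc1`, is not yet measured. It differs from compound 3 by 4-carboxyphenyl in place of 3-carboxyphenyl on a saturated ring carbon. This is the same kind of change as that from compound 1 to compound 2, but not the same: in compound 1 the place is on a saturated ring carbon of a three-membered non-aromatic ring of carbon only, next to the ring atom that bears a large group, whereas in compound 3 it is on a saturated ring carbon of a four-membered non-aromatic ring of carbon only, two ring bonds from the ring atom that bears a hydroxy group and two ring bonds from the ring atom that bears a large group. The change has one earlier instance, on the other core.

Because a number 9 percentage points lower from compound 1 to compound 2 (within the scatter) lay within the scatter, the step from compound 3 to compound 4 in this assay is expected to be of similar small size, a number 7 percentage points lower from compound 3 to compound 4 (within the scatter). Compound 4 is therefore estimated to give 42% in this assay, with a range from 25% to 58% expected.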

Compound 4, oral bioavailability in the Mus musculus assay: 41%
Estimate against measurement, compound 4: 1 percentage points above; the measured number falls inside the stated range.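

In the Mus musculus assay, compound 3 gives 49% and compound 4 gives 41%; 4-carboxyphenyl in place of 3-carboxyphenyl on a saturated ring carbon of the core of compound 3 gives a number 8 percentage points lower from compound 3 to compound 4 (within the scatter), and this step agrees with the earlier one on the core of compound 1: the same change on two cores in the Mus musculus assay, a number 9 percentage points lower (within the scatter) from compound 1 to compound 2 and a number 8 percentage points lower (within the scatter) from compound 3 to compound 4, 1 percentage points apart, within the scatter of two such steps On these two cores, then, the change carries over with a step of similar small size. In a physicochemical assay for solubility (on this read-out higher numbers stand for higher solubility and lower numbers for lower solubility), compound 3 gives 192000 nM and compound 4 gives 192000 nM, and the same pair shows no change at the digits printed from compound 3 to compound 4 (within the scatter). This does not show that 4-carboxyphenyl lowers oral bioavailability, since each step lies within the scatter, and two cores cannot establish a rule for the whole series; the solubility step, shown for one pair only, says nothing about carrying the change from core to core.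

The compounds shown leave open whether the change would behave in the same way on a core with an amine or a methoxy group in place of the hydroxy group on the four-membered ring. They also leave open what an amide or a tetrazole would give in place of the carboxylic acid on the phenyl ring.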